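Triazole N-aryl variation in the HepG2 urea series

A few compounds are considered here, and "the series" means these few. Any claim that something is new, unique, unknown or untested is made for them only; others in the source may bear on it.

Compound 1 `CC(C)c1cccc(-n2cc(COc3cccc(NC(=O)Nc4ccc(Cl)c(C(F)(F)F)c4)c3)nn2)c1` gives 3250 nM in a functional assay on HepG2 cells (Homo sapiens) for inhibition, read by MTT assay, with a stated time of 72 h; on this read-out lower numbers stand for stronger inhibition and higher numbers for weaker inhibition. Within the data shown here, compound 2 `O=C(Nc1cccc(OCc2cn(-c3ccccc3F)nn2)c1)Nc1ccc(Cl)c(C(F)(F)F)c1` gives 1520 nM and so stands lowest of the two numbers known, the only step being a 2.1-fold lower number from compound 1 to compound 2 (0.33 log units; beyond the scatter). Compound 3 `O=C(Nc1cccc(OCc2cn(-c3ccc(I)cc3)nn2)c1)Nc1ccc(Cl)c(C(F)(F)F)c1` differs from compound 2 only at that aromatic nitrogen: 4-iodophenyl in place of 2-fluorophenyl on an aromatic nitrogen. Among the measured compounds shown here, the one step that bears on this position, a 2.1-fold lower number from compound 1 to compound 2 (0.33 log units; beyond the scatter), was modest, so for compound 3 a step of a 1.3-fold higher number from compound 2 to compound 3 (0.12 log units; within the scatter) is expected, with no direction beyond the scatter to be claimed. Compound 3 is therefore estimated at 2000 nM, within 700 nM to 6000 nM.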

Compound 3, half-maximal inhibitory concentration: 2690 nM
For compound 3 the middle estimate is 1.3-fold (0.13 log units) below the measured one; the range from low to high includes it.
By their numbers in this assay, from the lowest: compounds 2, 3 and 1 (each within the scatter of the next, the first and the last beyond it).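

The step of a 1.8-fold higher number from compound 2 to compound 3 (0.25 log units; within the scatter) and the step of a 1.2-fold lower number from compound 1 to compound 3 (0.08 log units; within the scatter) both lie within the scatter, so 4-iodophenyl on this aromatic nitrogen cannot be separated from either 2-fluorophenyl or 3-isopropylphenyl. Only compound 1 and compound 2 stand apart, and the three aryl groups therefore give no clean ranking. Nothing at hand explains these numbers.

A 4-fluorophenyl group would separate the identity of the halogen from its place on the ring. From the compounds shown here alone, whether a phenyl ring carrying an amine or a carboxylic acid, or a cyclohexyl group, would move the number well beyond the scatter remains open.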